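One More Aryl Swap in a Flat Series

The source may hold more compounds than are shown below. What is called first, only, known or untested is meant among the compounds shown, and "the series" means these compounds.

In a functional assay on SW480 cells (Homo sapiens) for antiproliferative activity, read by sulforhodamine B assay, with a stated time of 48 h (on this read-out higher numbers stand for weaker inhibition and lower numbers for stronger inhibition), compound 1 (`COc1cc(C=C(C(=O)/C=C/c2cccc(OC)c2OC)C(=O)/C=C/c2cccc(OC)c2OC)ccc1O`) gives 430 nM, compound 2 (`COc1ccc(C=C(C(=O)/C=C/c2cccc(OC)c2OC)C(=O)/C=C/c2cccc(OC)c2OC)cc1OC`) gives 410 nM and compound 3 (`COc1cccc(/C=C/C(=O)C(=Cc2ccc(O)c(F)c2)C(=O)/C=C/c2cccc(OC)c2OC)c1OC`) gives 330 nM, so compound 3 stands within the scatter of the other two. Compound 4 (`COc1cc(C=C(C(=O)/C=C/c2cccc(OC)c2OC)C(=O)/C=C/c2cccc(OC)c2OC)cc(OC)c1O`) carries 4-hydroxy-3,5-dimethoxyphenyl in place of 3-fluoro-4-hydroxyphenyl on a double-bonded chain carbon bound to a double-bonded chain carbon. Three measured changes of this same aryl group bear on it: a 1.0-fold lower number from compound 1 to compound 2 (0.02 log units; within the scatter), a 1.3-fold lower number from compound 1 to compound 3 (0.11 log units; within the scatter) and a 1.2-fold lower number from compound 2 to compound 3 (0.09 log units; within the scatter). With all three within the scatter, the expected step is no larger than the scatter: a 1.2-fold higher number from compound 3 to compound 4 (0.08 log units; within the scatter). Compound 4 is estimated at 400 nM, with an expected range of 190 nM to 800 nM.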

Compound 4, half-maximal inhibitory concentration: 420 nM
Compound 4: middle estimate off by 1.1-fold (0.02 log units), on the low side; measured number inside the range.
By their numbers in this assay, from the lowest: compounds 3, 2, 4 and 1 (each within the scatter of the next).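

Compound 4 widens the range of aryl groups tolerated on a double-bonded chain carbon bound to a double-bonded chain carbon. In this assay, all three new steps stay within the scatter: a 1.3-fold higher number from compound 3 to compound 4 (0.10 log units; within the scatter), a 1.0-fold higher number from compound 2 to compound 4 (0.01 log units; within the scatter) and a 1.0-fold lower number from compound 1 to compound 4 (0.01 log units; within the scatter). Even the larger 4-hydroxy-3,5-dimethoxyphenyl group, with its added hydrogen-bond acceptors, produces no step beyond the scatter, and nothing available here accounts for this flatness. The compounds shown leave open whether an aryl group bearing an amine or a carboxylic acid would also stay within the scatter. They also leave open how a cyclohexyl group in place of the aryl ring would read.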